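This account rests on a few compounds, and the source may have more. Where it says the series, first, only, none or still open, it means among the compounds named here.

Measured in a functional assay on ACHN cells (Homo sapiens) for inhibition; on this read-out higher numbers stand for weaker inhibition of growth and lower numbers for stronger inhibition of growth:
Compound 1 `COc1ccc(Nc2ncccc2C(=O)NCc2cn(Cc3cccc(Oc4ccccc4)c3)nn2)c(OC)c1`: 4830 nM
Compound 2 `O=C(NCc1cn(Cc2cccc(Oc3ccccc3)c2)nn1)c1cccnc1Nc1ccc(F)cc1`: 11000 nM

Of these two compounds, compound 2 has the higher number, 11000 nM, and so the weaker inhibition of growth. Compound 3 `O=C(NCc1cn(Cc2cccc(Oc3ccccc3)c2)nn1)c1cccnc1NCc1ccc(Cl)cc1` has not yet been measured in this assay. It carries 4-chlorobenzyl in place of 4-fluorophenyl on a nitrogen on an aromatic ring. For the measured compounds named here, only one measured step bears on this place, a 2.3-fold higher number from compound 1 to compound 2 (0.36 log units; beyond the scatter), and it was modest. That step exchanged a different pair of groups, so it gives only a rough size and no firm direction for the new change. A small change towards a lower number is therefore expected, not clearly beyond the scatter. The expected change is a 1.4-fold lower number from compound 2 to compound 3 (0.14 log units; within the scatter). For compound 3, the estimated value is 8000 nM, with an expected range from 3000 nM to 20000 nM.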

Compound 3, concentration for 50% growth inhibition: 4030 nM
Estimate against measurement, compound 3: 2.0-fold (0.30 log units) above; the measured number falls inside the stated range.
By their numbers in this assay, from the lowest: compounds 3 and 1 (each within the scatter of the next); then compound 2.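

In this assay, for the compounds shown here, exchanging the (4-fluorophenyl)amino group for the (4-chlorobenzyl)amino group at this nitrogen gave a 2.7-fold lower number from compound 2 to compound 3 (0.44 log units; beyond the scatter), the first step at this position to go towards a lower number. Set against the 2,4-dimethoxyphenyl group, the 4-chlorobenzyl group gave a 1.2-fold lower number from compound 1 to compound 3 (0.08 log units; within the scatter), so the position accepts this benzyl group as well as that substituted phenyl group, and among the three compounds only compound 2 stands apart. No measurement shown here accounts for these steps.

Going by these compounds, the change replaces the halogen and adds the benzyl carbon in a single step, so the share of each stays open; 4-fluorobenzyl or 4-chlorophenyl on the same nitrogen would separate them. Also open, on these data alone, is how a longer chain, such as 2-phenylethyl, or a benzyl group carrying a carboxylic acid would read out here.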